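Methyl scan on the benzimidazole-pyrazolone series

This account rests on a few compounds, and the source may have more. Where it says the series, first, only, none or still open, it means among the compounds named here.

Measured compounds and their values:
compound 1 `Cc1ccc2[nH]c(-n3[nH]c(C)c(Cc4ccccc4)c3=O)nc2c1` gives 670 nM
compound 2 `Cc1ccc2[nH]c(-n3[nH]c(C)c(Cc4ccc(C(F)(F)F)cc4)c3=O)nc2c1` gives 570 nM
compound 3 `Cc1[nH]n(-c2nc3ccccc3[nH]2)c(=O)c1Cc1ccc(C(F)(F)F)cc1` gives 550 nM

All three numbers come from an assay on isolated protein for inhibition of alpha-ketoglutarate-dependent dioxygenase alkB homolog 3 (Homo sapiens), read by polymerase chain reaction, with a stated time of 1 h; a lower number here means a stronger inhibitor, a higher number a weaker inhibitor. The three values sit close together: compound 1 stands with a 1.2-fold lower number from compound 1 to compound 2 (0.07 log units; within the scatter), and compound 3 with a 1.0-fold higher number from compound 3 to compound 2 (0.02 log units; within the scatter). The step from compound 1 to compound 2 is trifluoromethyl in place of hydrogen on an aromatic carbon; the step from compound 3 to compound 2 is methyl in place of hydrogen on an aromatic carbon. The difference between the cores of compound 1 and compound 3 is not broken down here.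

Compound 4 `Cc1ccc2[nH]c(-n3[nH]c(C)c(Cc4ccccc4)c3=O)nc2c1C` is not yet measured in this assay. It differs from compound 1 by methyl in place of hydrogen on an aromatic carbon. Among the measured compounds shown here, this is the same kind of change as the one from compound 3 to compound 2, but not the same: there the methyl enters at a place meta to a fused ring and para to a fused ring, whereas in compound 4 it enters ortho to a fused ring, ortho to a methyl group and meta to a fused ring. For the measured compounds named here, the only guide is the step from compound 3 to compound 2, which lay within the scatter; on that basis compound 4 is expected to show a 1.1-fold lower number from compound 1 to compound 4 (0.03 log units; within the scatter), because a 1.0-fold higher number from compound 3 to compound 2 (0.02 log units; within the scatter) gave no movement of note. The estimate for compound 4 in this assay is 620 nM, with a range from 300 nM to 1300 nM.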

Compound 4, half-maximal inhibitory concentration: > 10000 nM
Compound 4: only a limit was reported (the forecaster's own chance of this, stated with the estimate: 2%); middle value at least 16-fold (1.20 log units) from the limit.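

In this assay, methyl in place of hydrogen on the aromatic carbon ortho to a fused ring, ortho to a methyl group and meta to a fused ring gives an at least 14-fold higher number from compound 1 to compound 4 (1.17 log units; beyond the scatter), so this change does not carry unchanged from one core to another in this series: the same change on two cores in this assay, a 1.0-fold higher number (0.02 log units; within the scatter) from compound 3 to compound 2 and an at least 14-fold higher number (1.17 log units; beyond the scatter) from compound 1 to compound 4, at least 14-fold (1.15 log units) apart, beyond the scatter of two such steps. Going by these compounds, compound 4 gives > 10000 nM, which is a limit of the assay and not a number, so the full size of the step stays unknown: the limit of > 10000 nM in this assay, at which 1 of the 4 values shown sits. The two methyl steps differ both in the core and in the place where the methyl enters, and with one step on each, they do not show whether the core, the place or both set the gap, nor do they give a rule for methyl groups elsewhere on these cores.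

Still open, on these data alone, is whether a fluorine, a chlorine, a methoxy group or an ethyl group on the same aromatic carbon would give a number like that of compound 1 or a limit like that of compound 4. Also open, as far as these compounds go, is whether the same methyl has a comparable effect when added to compound 2, which carries trifluoromethyl, or when it stands without the neighbouring methyl group.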